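The source may hold more compounds than are shown below. What is called first, only, known or untested is meant among the compounds shown, and "the series" means these compounds.

Measured in an assay on isolated protein for displacement of a labelled ligand from metabotropic glutamate receptor 5 (Homo sapiens), with a stated time of 60 min, tested at 1 uM; a lower number here means less inhibition, a higher number more inhibition at the concentration tested (going by the name of the read-out):
compound 1, `CC1CCN(c2c(S(=O)(=O)c3cc(F)cc(F)c3)cnc3c(F)cccc23)CC1` — 9%
compound 2, `CC1CCN(c2c(S(=O)(=O)c3ccc(F)c(F)c3)cnc3cc(Cl)ccc23)CC1` — 90%
compound 3, `CC1CCN(c2c(S(=O)(=O)c3ccc(Cl)cc3)cnc3cc(Cl)ccc23)CC1` — 91%

Compound 1 stands lowest of the three; compound 2 and compound 3 both sit far above it, beyond the scatter. Compound 4, `CC1CCN(c2c(S(=O)(=O)c3ccc(F)c(F)c3)cnc3c(F)cccc23)CC1`, keeps the core of compound 1 and changes only the group on the sulfonyl sulfur: 3,4-difluorophenyl in place of 3,5-difluorophenyl on a sulfonyl sulfur. Among the compounds with values here, one measured step bears on this spot: a number 1 percentage points higher from compound 2 to compound 3 (within the scatter), a change of the same group on the same sulfur that left the read-out unchanged. Within the data shown here, compound 2 and compound 3, however, share a core unlike that of compound 1, so no measured step shows how that core responds. Compound 4 is therefore expected to stay close to compound 1, with a number 9 percentage points higher from compound 1 to compound 4 (within the scatter). The estimate for compound 4 is 18%, within 3% to 50%.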

Compound 4, a percentage reported as inhibition, at one concentration (the size of the read-out at that concentration, not a potency): 93%
Beside the measured number, compound 4's estimate is 75 percentage points below it; measured number above the stated range.
By their numbers in this assay, from the lowest: compound 1; then compounds 2, 3 and 4 (each within the scatter of the next).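

In this assay, the swap of 3,5-difluorophenyl for 3,4-difluorophenyl on the core of compound 1 gives a number 84 percentage points higher from compound 1 to compound 4 (beyond the scatter), although the two compounds have the same atoms, joined differently. Within the data shown here, the only earlier step at this sulfonyl sulfur, a number 1 percentage points higher from compound 2 to compound 3 (within the scatter), came from a different core and gave no sign that the read-out could depend so strongly on this group. Nothing available explains the size of this step.

As far as these compounds go, whether 3,5-difluorophenyl would give an equally low number on the core of compound 2 stays open. So does the outcome with a plain phenyl or a cyclohexyl group on the sulfonyl sulfur.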